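The source may report more compounds than this note shows. Statements on the series, on what has been measured and on what is new or still open speak of the compounds shown alone.

Values in a functional assay on the whole organism (strain Wistar albino) for inhibition, with Rattus norvegicus as the target, read by paw edema, with stated times of 1 h and 3 h, at a dose of 0.32 mmol/kg by the intraperitoneal route; a higher number here means more inhibition at the dose given (going by the name of the read-out), a lower number less inhibition:
Compound 1 `Cc1ccc(-c2nn(-c3ccc(S(N)(=O)=O)cc3)cc2/C=N\c2ccc(Cl)cc2)cc1` gives 78.4%.
Compound 2 `COc1ccc(-c2nn(-c3ccc(S(N)(=O)=O)cc3)cc2/C=N\c2ccc(Cl)cc2)cc1` gives 62.8%.
Compound 3 `Cc1ccc(-c2nn(-c3ccc(S(N)(=O)=O)cc3)cc2-c2cc(-c3ccc(Cl)cc3)[nH]c2-c2ccc(F)cc2)cc1` gives 66.7%.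

Compound 1 and compound 2 share one core and differ in a single place: methoxy in place of methyl on an aromatic carbon. This change produces a number 15.6 percentage points lower from compound 1 to compound 2 (beyond the scatter). Compound 3 carries another core; the difference between the core of compound 1 and the core of compound 3 is not broken down here. The numbers of compound 3 and compound 2 lie within the scatter of each other, while the number of compound 1 is higher than that of compound 3 by more than the scatter.

Compound 4 `COc1ccc(-c2nn(-c3ccc(S(N)(=O)=O)cc3)cc2-c2cc(-c3ccc(Cl)cc3)[nH]c2-c2ccc(F)cc2)cc1` is not yet measured. It relates to compound 3 exactly as compound 2 relates to compound 1: methoxy in place of methyl on an aromatic carbon. The place is the same word for word, so this is the same change, now made on the core of compound 3. Among the compounds with values here, only one measured pair shows the change, so the transfer rests on that single case. The step in this assay is expected to be a number 12.7 percentage points lower from compound 3 to compound 4 (beyond the scatter), a little smaller than the measured one because the earlier step was a number 15.6 percentage points lower from compound 1 to compound 2 (beyond the scatter) on a different core. Compound 4 is therefore expected at 54% in this assay, with a likely range from 42% to 66%.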

Compound 4, a percentage reported as inhibition, in the whole organism at one dose (the size of the read-out at that dose, not a potency): 55.9%
Estimate against measurement, compound 4: 1.9 percentage points below; measured number inside the range.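

In this assay the change from 4-methylphenyl to 4-methoxyphenyl on the core of compound 3 gives a number 10.8 percentage points lower from compound 3 to compound 4 (beyond the scatter) and so repeats the direction seen on the core of compound 1. Within this series the change carries from one core to the other in direction, and the two steps do not differ in size: the same change on two cores in this assay, a number 15.6 percentage points lower (beyond the scatter) from compound 1 to compound 2 and a number 10.8 percentage points lower (beyond the scatter) from compound 3 to compound 4, 4.8 percentage points apart, within the scatter of two such steps. Within the data shown here, this rests on only two pairs, so it sets no rule for any further core, and these percentages at a single dose are not potencies and give no reason for the lower number.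

The compounds shown carry only methyl or methoxy at this place, so it remains open how an ethoxy, a hydroxyl, a dimethylamino or a carboxylic acid group there would read in this assay. Also open, from the compounds shown here alone, is whether the step from methyl to methoxy keeps its direction and size on a third core.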